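The source may hold more compounds than are shown below. What is called first, only, known or untested is meant among the compounds shown, and "the series" means these compounds.

In a functional assay on NCI-H460 cells (Homo sapiens) for inhibition, read by MTT assay, with a stated time of 24 h, tested at 0.1 ug/mL (a higher number here means more inhibition of growth at the concentration tested, a lower number less inhibition of growth), compound 1 `O=C(CCCCC(S)CCS)NO` gives 5.7% and compound 2 `O=C(CCCCC1CCSS1)Nc1ccccn1` gives 2.61% while compound 3 `O=C(CCCCC(S)CCS)Nc1ccccc1` gives 5.5% and so stands level with both, all three lying within the scatter of one another. Compound 4 `O=C(CCCCC(S)CCS)Nc1ccccn1` carries pyridin-2-yl in place of phenyl on an amide-type nitrogen. For the measured compounds named here, the one measured step at this nitrogen, a number 0.2 percentage points lower from compound 1 to compound 3 (within the scatter) with phenyl in place of hydroxy, also stays within the scatter. Compound 2 already bears pyridin-2-yl there, and its value (2.61%) shows no separation from the others. No step beyond the scatter is therefore expected in this assay. The estimated change is a number 0.5 percentage points lower from compound 3 to compound 4 (within the scatter) and would be within the scatter. Compound 4 is expected at 5% (estimated range 0.5% to 12%).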

Compound 4, percent growth inhibition at one concentration: 5.01%
Compound 4: middle estimate off by 0 percentage points, on the low side, within the range that was stated.
By their numbers in this assay, from the lowest: compounds 2, 4, 3 and 1 (each within the scatter of the next).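

In this assay, pyridin-2-yl on the amide-type nitrogen stands level with phenyl (a number 0.5 percentage points lower from compound 3 to compound 4 (within the scatter)) and with hydroxy (a number 0.7 percentage points lower from compound 1 to compound 4 (within the scatter)), so adding a hydrogen-bond acceptor to the group at this place gives no readable difference. With pyridin-2-yl held fixed, the open chain group in place of the five-membered ring gives no readable difference either (a number 2.4 percentage points higher from compound 2 to compound 4 (within the scatter)). No measured evidence accounts for these readings. The compounds shown leave open whether an amine, a carboxylic acid or a benzyl group on this nitrogen would separate from the scatter.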